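Swapping sulfur for oxygen in a side chain

The source may hold more compounds than are shown below. What is called first, only, known or untested is meant among the compounds shown, and "the series" means these compounds.

Of the compounds shown here, three have been tested in a functional assay on THP-1 cells (Homo sapiens); a lower number here means a smaller maximal response, a higher number a larger maximal response. Compound 1, `CCSC[C@@](O)([C@@H](Nc1cccc2nc(C)ccc12)c1cccc(F)c1OC)C(F)(F)F`, gives 69%. Compound 2, `COc1ccc([C@H](Nc2cccc3nc(C)ccc23)[C@](O)(CC#N)C(F)(F)F)c(Cl)c1F`, gives 83%. Compound 3, `CCSC[C@@](O)([C@@H](Nc1cc(F)cc2[nH]c(=O)ccc12)c1ccc(OC)c(F)c1Cl)C(F)(F)F`, gives 93%. The number for compound 3 is the top one of the three, yet its gap to compound 2 lies within the usual scatter of this assay, so the two cannot be told apart; only the gap to compound 1 lies beyond the scatter. Each of the three also differs from the others in more than one place, so no single change can be read from them.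

Compound 4, `CCOC[C@@](O)([C@@H](Nc1cc(F)cc2[nH]c(=O)ccc12)c1ccc(OC)c(F)c1Cl)C(F)(F)F`, differs from compound 3 in exactly one place: ethoxy in place of ethylsulfanyl on a saturated chain carbon, two bonds along the chain from an oxygen on a saturated carbon. In words of size, an ethylsulfanyl group makes way for an ethoxy group on a saturated chain carbon, two bonds along the chain from an oxygen on a saturated carbon; the count of heavy atoms, donors and acceptors stays the same.

Within the data shown here, no measured pair shows what such a swap does here. Without that, the expected step from compound 3 to compound 4 in this assay is a number 5 percentage points lower from compound 3 to compound 4 (within the scatter), within the scatter. Compound 4 is therefore estimated at 88%, in a range from 72% to 100%.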

Compound 4, largest response reached (Emax), in percent of the reference or control that the assay uses in the THP-1 assay: 99%
Compound 4: the middle estimate sits 11 percentage points below what was measured; the measured number falls inside the stated range.
By their numbers in the THP-1 assay, from the lowest: compound 1; then compounds 2, 3 and 4 (each within the scatter of the next, the first and the last beyond it).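

In the THP-1 assay the exchange of ethylsulfanyl for ethoxy reads as a number 6 percentage points higher from compound 3 to compound 4 (within the scatter), so this pair shows no difference in maximal response that can be told apart from the ordinary spread of repeated measurements. In a physicochemical assay for lipophilicity (a lower number here means a more polar compound, a higher number a more lipophilic compound), compound 3 gives 4.3 and compound 4 gives 3.8, which is a number 0.50 log units lower from compound 3 to compound 4 (beyond the scatter). Together these results show something the earlier compounds, each differing from the others in more than one place, could not show: at this saturated chain carbon, putting oxygen in place of sulfur gives a less lipophilic compound while the maximal response stays within the scatter: the measured partition coefficient of compound 3, 4.3, and of compound 4, 3.8, a number 0.50 log units lower (beyond the scatter)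

The compounds shown leave open whether other groups in this place, such as a longer chain or an amine, would also keep the maximal response in the THP-1 assay. Among these compounds, they also leave open whether the same swap would give a similar result on a different core, such as that of compound 1, as this single pair is the only evidence for the change.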